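Notes on a cyanophenyl replacement in compound 3

The source may report more compounds than this note shows. Statements on the series, on what has been measured and on what is new or still open speak of the compounds shown alone.

Measured so far:
compound 1, `CCCCc1cnc(C(CCC)Cc2ccc(-c3ccccc3C(=O)O)cc2)[nH]1`: 1180 nM
compound 2, `Cc1cccc(Cc2cnc(CCc3ccc(-c4ccccc4C(=O)O)cc3)[nH]2)c1`: 4310 nM

In an in vitro functional assay on cells for agonist activity at Bombesin receptor subtype-3 (Homo sapiens), read by luminescence and calcium flux (a lower number here means that less compound is needed, a higher number that more compound is needed for the effect), compound 2 gives 4310 nM, the higher of the two numbers; compound 1 gives 1180 nM, and the gap between them lies beyond the scatter. Compound 3, `N#Cc1ccccc1Cc1cnc(CCc2ccc(-c3ccccc3C(=O)O)cc2)[nH]1`, differs from compound 2 by 2-cyanophenyl in place of 3-methylphenyl on a saturated chain carbon bound to an aromatic carbon. For the measured compounds named here, no measured step of this kind exists, so the step of a 1.2-fold lower number from compound 2 to compound 3 (0.09 log units; within the scatter) is expected to stay within the scatter, with no firm direction. Compound 3 is therefore expected to give about 3500 nM, between 1200 nM and 10000 nM, in this assay.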

Compound 3, half-maximal effective concentration: 5480 nM
Compound 3: the middle estimate sits 1.6-fold (0.19 log units) below what was measured; low and high end bracket the measured number.
By their numbers in this assay, from the lowest: compound 1; then compounds 2 and 3 (each within the scatter of the next).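

In this assay, 2-cyanophenyl in place of 3-methylphenyl on a saturated chain carbon bound to an aromatic carbon gives a 1.3-fold higher number from compound 2 to compound 3 (0.10 log units; within the scatter). This position therefore takes a nitrile-bearing ring in exchange for a methyl-bearing one with no step beyond the scatter, even with the added hydrogen-bond acceptor. Nothing on hand explains this outcome. Still open, as far as these compounds go, is whether this tolerance extends to other groups on that carbon, such as an aminophenyl group or a longer alkyl chain. A single step cannot separate the effect of the nitrile from that of its place on the ring.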